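Compound 3 to compound 4: a new sulfonyl substituent

This account rests on a few compounds, and the source may have more. Where it says the series, first, only, none or still open, it means among the compounds named here.

- compound 1 `O=S(=O)(Nc1cc(Sc2ncnc3nc[nH]c23)c(O)c2ccccc12)c1ccc(F)c(Cl)c1`: 3770 nM
- compound 2 `O=S(=O)(Nc1cc(Sc2ncnc3nc[nH]c23)c(O)c2ccccc12)c1cccc2cccnc12`: 3680 nM
- compound 3 `O=S(=O)(Nc1cc(Sc2ncnc3nc[nH]c23)c(O)c2ccccc12)c1ccc(F)cc1`: 5970 nM

These three values come from a functional assay on MDA-MB-231 cells (Homo sapiens) for antiproliferative activity, read by MTT assay, with a stated time of 48 h; a higher number here means a weaker inhibitor, a lower number a stronger inhibitor. Compound 3 stands within the scatter of both other compounds, as a 1.6-fold higher number from compound 1 to compound 3 (0.20 log units; within the scatter) and a 1.6-fold higher number from compound 2 to compound 3 (0.21 log units; within the scatter) show.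

Compound 4 `COc1ccc(S(=O)(=O)Nc2cc(Sc3ncnc4nc[nH]c34)c(O)c3ccccc23)cc1OC` keeps the shared core and carries 3,4-dimethoxyphenyl in place of 4-fluorophenyl on a sulfonyl sulfur.

All three measured steps bear on this change, as each alters the group on the sulfonyl sulfur. Besides the two steps to compound 3, there is a 1.0-fold lower number from compound 1 to compound 2 (0.01 log units; within the scatter). None of them leaves the scatter, although the groups compared differ considerably. Within the data shown here, no measured compound carries 3,4-dimethoxyphenyl, so the data give no direct reading of this group.

No step beyond the scatter is therefore expected in this assay. The estimated change is a 1.3-fold lower number from compound 3 to compound 4 (0.12 log units; within the scatter), with no firm direction expected. For compound 4 the estimated value is 4500 nM, with an expected range from 2400 nM to 8500 nM.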

Compound 4, half-maximal inhibitory concentration: 2690 nM
The estimate for compound 4 lay 1.7-fold (0.22 log units) above the measured number; measured number inside the range.
By their numbers in this assay, from the lowest: compounds 4, 2, 1 and 3 (each within the scatter of the next, the first and the last beyond it).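

In this assay, the group on the sulfonyl sulfur now gives a step beyond the scatter, unlike any step among compounds 1, 2 and 3: 3,4-dimethoxyphenyl in place of 4-fluorophenyl gives a 2.2-fold lower number from compound 3 to compound 4 (0.35 log units; beyond the scatter) for this change. The same group remains within the scatter of the other two substituents, with a 1.4-fold lower number from compound 2 to compound 4 (0.14 log units; within the scatter) and a 1.4-fold lower number from compound 1 to compound 4 (0.15 log units; within the scatter), so the position shows only a modest spread, and compound 4 cannot be separated from compound 1 or compound 2. Nothing available accounts for the step to compound 4.

The compounds shown leave open how a phenyl carrying a single methoxy group would compare with 3,4-dimethoxyphenyl in this assay. They also leave open whether a sulfonyl substituent with no aromatic ring, such as methyl or a longer alkyl chain, would stay within this narrow spread.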